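Cyclopentyl for sec-butyl on the cyanoguanidine nitrogen

The source may hold more compounds than are shown below. What is called first, only, known or untested is meant among the compounds shown, and "the series" means these compounds.

Within the data shown here, the three compounds measured so far share one core and differ only in the alkyl group carried on the double-bonded nitrogen. In a functional assay on the whole organism (blood, strain Wistar-Okamoto) with Rattus norvegicus as the target, with a stated time of 5 days (a lower number here means that less compound is needed, a higher number that more compound is needed for the effect), compound 1 `CCC/N=C(\NC#N)Nc1cccnc1` gives 20 mg/kg. Compound 2 `CC(C)/N=C(\NC#N)Nc1cccnc1` gives 2.5 mg/kg, and compound 3 `CCC(C)/N=C(\NC#N)Nc1cccnc1` gives 20 mg/kg. Compound 3 therefore stands level with compound 1 at the digits reported, the two together at the high end of the three numbers, while an 8.0-fold higher number from compound 2 to compound 3 (0.90 log units; beyond the scatter).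

Compound 4 `N#CN/C(=N\C1CCCC1)Nc1cccnc1` is the next member. cyclopentyl in place of sec-butyl on a double-bonded nitrogen The group that leaves, sec-butyl, and the one that enters, cyclopentyl, both branch at the carbon bound to the nitrogen, and the entering group closes a five-membered ring of carbon only.

Among the measured compounds shown here, no measured step covers a ring in this position. For the measured compounds named here, the steps that bear on it concern branching and size: an 8.0-fold lower number from compound 1 to compound 2 (0.90 log units; beyond the scatter), whereas no change at the digits printed from compound 1 to compound 3 (within the scatter). Branching alone is thus not enough to account for the low number of compound 2, and a further increase in size did not lower it. For compound 4 one expects at most a modest change, a 2.0-fold lower number from compound 3 to compound 4 (0.30 log units; within the scatter), within the scatter or slightly beyond it. The estimate for compound 4 is 10 mg/kg, in a range from 2.5 mg/kg to 40 mg/kg.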

Compound 4, minimum effective dose: 20 mg/kg
Compound 4: the middle estimate sits 2.0-fold (0.30 log units) below what was measured; the measured number falls inside the stated range.
By their numbers in this assay, from the lowest: compound 2; then compounds 1, 3 and 4 (each within the scatter of the next).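

In this assay the closed ring gives no change at the digits printed from compound 3 to compound 4 (within the scatter), and the comparison with the straight chain reads the same, with no change at the digits printed from compound 1 to compound 4 (within the scatter). Cyclopentyl is the first ring seen on this double-bonded nitrogen, and it joins propyl and sec-butyl as a third group that does not share the low number of the isopropyl compound, with an 8.0-fold higher number from compound 2 to compound 4 (0.90 log units; beyond the scatter). Nothing at hand explains why isopropyl alone stands apart from the other three groups.

The compounds shown leave open whether the low number belongs to isopropyl alone or would return with other small groups such as cyclopropyl or tert-butyl on this nitrogen. Also open, as far as these compounds go, is what a larger ring such as cyclohexyl, or a cyclopentyl ring carrying a hydroxyl group or an amine, would give here, and whether the same steps would hold with a change elsewhere on the shared core.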